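Methyl-for-hydrogen steps on two related cores

This account rests on a few compounds, and the source may have more. Where it says the series, first, only, none or still open, it means among the compounds named here.

Compound 1 `CC(C)c1nc2c(OCc3ccccc3)cccn2c1N` gives 2.7 mg/kg in a functional assay on the whole organism with Rattus norvegicus as the target; a lower number here means that less compound is needed, a higher number that more compound is needed for the effect. Compound 2 `CC(C)(C)c1nc2c(OCc3ccccc3)cccn2c1N` carries the change methyl in place of hydrogen on a saturated chain carbon bound to an aromatic carbon and two saturated chain carbons and gives 15 mg/kg; the step of a 5.6-fold higher number from compound 1 to compound 2 (0.74 log units; beyond the scatter) follows. Compound 3 `CCNc1c(C)nc2c(OCc3ccccc3)cccn12` gives 3.5 mg/kg, within the scatter of compound 1; the difference between the two cores is not broken down here. Compound 4 `CCCNc1c(C)nc2c(OCc3ccccc3)cccn12` carries the change (methyl in place of hydrogen on a saturated chain carbon, two bonds along the chain from a nitrogen on an aromatic ring). This is the same kind of change as in compound 2, but the place differs: in compound 2 the carbon is bound to an aromatic carbon and two saturated chain carbons, in compound 4 it sits two bonds along the chain from a nitrogen on an aromatic ring. A smaller rise, a 1.7-fold higher number from compound 3 to compound 4 (0.23 log units; within the scatter), is expected from compound 3 to compound 4, resting on the step of a 5.6-fold higher number from compound 1 to compound 2 (0.74 log units; beyond the scatter) at a different place. For compound 4 the expected value is 6 mg/kg, between 2.5 mg/kg and 15 mg/kg.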

Compound 4, dose for half-maximal effect: 5.3 mg/kg
The estimate for compound 4 lay 1.1-fold (0.05 log units) above the measured number; low and high end bracket the measured number.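

In this assay, the change from ethylamino to propylamino gives a 1.5-fold higher number from compound 3 to compound 4 (0.18 log units; within the scatter). Set beside the methyl-for-hydrogen step on the core of compound 1, the change does not carry over in size: the same change on two cores in this assay, a 5.6-fold higher number (0.74 log units; beyond the scatter) from compound 1 to compound 2 and a 1.5-fold higher number (0.18 log units; within the scatter) from compound 3 to compound 4, 3.7-fold (0.56 log units) apart, beyond the scatter of two such steps This shows that a step read on one core does not predict the size of the step on the other in this series; it does not show whether the core or the place of the methyl accounts for the gap, as the two differ together, and one pair per core gives no general rule.

Still open, going by these compounds, is how a longer chain such as butylamino would read on the core of compound 3. On these data alone, a branched chain such as isopropylamino on that core also remains open.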